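This account rests on a few compounds, and the source may have more. Where it says the series, first, only, none or still open, it means among the compounds named here.

Measured compounds:
compound 1, `COC(=O)N[C@H](C(=O)N1CCC[C@H]1C(=O)Nc1ccc([C@H]2CC[C@H](c3ccc(NC(=O)[C@@H]4CCCN4C(=O)[C@@H](NC(=O)OC)C(C)C)cc3)N2c2ccc(C(F)(F)F)cc2)cc1)C(C)C`: 370 ng.h/mL
compound 2, `COC(=O)N[C@H](C(=O)N1CCC[C@H]1C(=O)Nc1ccc([C@H]2CC[C@H](c3ccc(NC(=O)[C@@H]4CCCN4C(=O)[C@@H](NC(=O)OC)C(C)(C)C)cc3)N2c2ccc(F)cc2)cc1)C(C)(C)C`: 18300 ng.h/mL

In an ADME assay on the whole organism (plasma) for pharmacokinetics, with Canis familiaris (Canis lupus familiaris) as the target, at a dose of 2.5 mg/kg by the oral route (a lower number here means less compound in the circulation, a higher number more compound in the circulation at the dose given), compound 1 gives 370 ng.h/mL, the lower of the two numbers, while compound 2 gives 18300 ng.h/mL, a gap far beyond the scatter. Compound 3, `COC(=O)N[C@H](C(=O)N1CCC[C@H]1C(=O)Nc1ccc([C@H]2CC[C@H](c3ccc(NC(=O)[C@@H]4CCCN4C(=O)[C@@H](NC(=O)OC)C(C)C)cc3)N2c2ccc(F)cc2)cc1)C(C)C`, has not been measured. It differs from compound 1 by fluoro in place of trifluoromethyl on an aromatic carbon. Among the measured compounds shown here, no pair of measured compounds isolates this change, and compound 2 carries fluoro but also differs elsewhere. A rise beyond the scatter is expected, a 6.8-fold higher number from compound 1 to compound 3 (0.83 log units; beyond the scatter), because compound 2 reaches 18300 ng.h/mL. Compound 3 is expected to give 2500 ng.h/mL, between 600 ng.h/mL and 10000 ng.h/mL.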

Compound 3, area under the concentration-time curve in the Canis familiaris assay: 1280 ng.h/mL
Compound 3: middle estimate off by 2.0-fold (0.29 log units), on the high side, and the stated range covers the measured number.
By their numbers in the Canis familiaris assay, from the lowest: compound 1; then compound 3; then compound 2.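

In the Canis familiaris assay compound 1 gives 370 ng.h/mL and compound 3 gives 1280 ng.h/mL. Among the compounds shown here, in the Canis familiaris assay, fluoro in place of trifluoromethyl on an aromatic carbon, para to a large group, with nothing else altered, gives a 3.5-fold higher number from compound 1 to compound 3 (0.54 log units; beyond the scatter) and thus shows for the first time that this change alone moves the read-out. In a physicochemical assay for solubility, in phosphate buffer, measured as kinetic solubility, at pH 7.2 (a lower number here means a less soluble compound, a higher number a more soluble compound), compound 1 gives 3200 nM and compound 3 gives 6000 nM. In the physicochemical assay the same change gives a 1.9-fold higher number from compound 1 to compound 3 (0.27 log units; within the scatter) and so does not separate the two compounds. Nothing shown here explains the step. Open, on these data alone, is how chloro, methoxy or a nitrile on this carbon would read in the Canis familiaris assay and whether the step would hold with other groups elsewhere on the shared core.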